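Ethoxycarbonyl for Methylsulfonyl on the Piperazine Nitrogen

The source may report more compounds than this note shows. Statements on the series, on what has been measured and on what is new or still open speak of the compounds shown alone.

Measured compounds:
compound 1 `Cc1cccc(-c2nnc3ccc(N4CCN(S(C)(=O)=O)CC4)nn23)c1`: 10.8 ug/mL
compound 2 `Cc1cccc(-c2nnc3ccc(N4CCN(C(c5ccccc5)c5ccccc5)CC4)nn23)c1`: 1.75 ug/mL
compound 3 `Cc1cccc(-c2nnc3ccc(N4CCN(C(=O)OC(C)(C)C)C(Cc5ccccc5)C4)nn23)c1`: 15.8 ug/mL

Of the compounds shown here, three sharing one core have been tested in a functional assay for inhibition, read by spectrophotometry, with a stated time of 60 min; on this read-out higher numbers stand for weaker inhibition and lower numbers for stronger inhibition. Compound 1 gives 10.8 ug/mL, the second highest of the three numbers. Its nearest neighbour is compound 3, whose value of 15.8 ug/mL lies within the scatter of compound 1, so no order between these two can be read. Compound 2, at 1.75 ug/mL, sits furthest from compound 1, and that gap is beyond the scatter.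

The next compound, compound 4 `CCOC(=O)N1CCN(c2ccc3nnc(-c4cccc(C)c4)n3n2)CC1`, has not yet been measured in this assay. It differs from compound 1 in one place: ethoxycarbonyl in place of methylsulfonyl on an amine nitrogen in a ring. For the measured compounds named here, no single-point step between measured compounds is available to calibrate this change; what the data show is only that compound 3, which also carries a carbamate on the ring nitrogen, returns a value close to that of compound 1.

On that basis compound 4 is expected to stay close to compound 1, with a step of a 1.1-fold higher number from compound 1 to compound 4 (0.05 log units; within the scatter), not beyond the scatter in either direction. The estimate for compound 4 in this assay is 12 ug/mL, within a range from 5 ug/mL to 30 ug/mL.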

Compound 4, half-maximal inhibitory concentration: 1 ug/mL
The estimate for compound 4 lay 12-fold (1.08 log units) above the measured number, outside the stated range (below it).
By their numbers in this assay, from the lowest: compounds 4 and 2 (each within the scatter of the next); then compounds 1 and 3 (each within the scatter of the next).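

In this assay, ethoxycarbonyl in place of methylsulfonyl on an amine nitrogen in a ring gives an 11-fold lower number from compound 1 to compound 4 (1.03 log units; beyond the scatter). For the compounds shown here, this is the first single change, and it shows that the number can move well beyond the scatter through the group on this nitrogen alone, which the earlier compounds, none differing from another in only one place, could not show. The two groups have the same count of hydrogen-bond acceptors and donors, so those counts do not separate them, and nothing available here explains the size of the step.

From the compounds shown here alone, it remains open whether the step follows the carbonyl, the ester oxygen or the ethyl part of the new group. A methoxycarbonyl, an acetyl or a urea on the same nitrogen would begin to separate these, as would a longer chain in place of the ethyl.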